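This account rests on a few compounds, and the source may have more. Where it says the series, first, only, none or still open, it means among the compounds named here.

Three compounds of this set share one core and differ only in the aryl group on a double-bonded chain carbon bound to a double-bonded chain carbon. Compound 1 `Cc1ccc(S(=O)(=O)NC(=O)Nc2ccccc2C(=O)/C=C/c2cccc(O)c2)cc1` gives 39.3 ug/mL in an ADME assay on the whole organism for cytotoxicity, with Artemia salina as the target, with a stated time of 24 h; on this read-out higher numbers stand for an effect only at larger amounts of compound and lower numbers for an effect already at smaller amounts. Compound 2 `COc1cc(/C=C/C(=O)c2ccccc2NC(=O)NS(=O)(=O)c2ccc(C)cc2)ccc1O` gives 17.8 ug/mL in this assay, and compound 3 `Cc1ccc(S(=O)(=O)NC(=O)Nc2ccccc2C(=O)/C=C/c2ccc[nH]2)cc1` gives 32.1 ug/mL. Compound 3 stands second highest of the three numbers; its nearest neighbour is compound 1 and its furthest is compound 2, both within the scatter of it. Among the measured steps, a 2.2-fold lower number from compound 1 to compound 2 (0.34 log units; beyond the scatter) was the only one beyond the scatter, while a 1.2-fold lower number from compound 1 to compound 3 (0.09 log units; within the scatter) and a 1.8-fold higher number from compound 2 to compound 3 (0.26 log units; within the scatter) stayed within it.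

Compound 4 `Cc1ccc(S(=O)(=O)NC(=O)Nc2ccccc2C(=O)/C=C/c2ccncc2)cc1` carries the change (pyridin-4-yl in place of 1H-pyrrol-2-yl on a double-bonded chain carbon bound to a double-bonded chain carbon). Within the data shown here, no measured step involves pyridin-4-yl, so the three aryl swaps above are the only guide, and two of those three moved little. Compound 4 is therefore expected to stay close to compound 3 in this assay, with a step of a 1.1-fold lower number from compound 3 to compound 4 (0.03 log units; within the scatter) that would fall within the scatter. The estimate for compound 4 is 30 ug/mL, with a range from 12 ug/mL to 75 ug/mL.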

Compound 4, concentration for half-maximal effect: 16.8 ug/mL
Beside the measured number, compound 4's estimate is 1.8-fold (0.25 log units) above it; the range from low to high includes it.
By their numbers in this assay, from the lowest: compounds 4, 2, 3 and 1 (each within the scatter of the next, the first and the last beyond it).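

In this assay, pyridin-4-yl on a double-bonded chain carbon bound to a double-bonded chain carbon stays within the scatter of the 1H-pyrrol-2-yl group (a 1.9-fold lower number from compound 3 to compound 4 (0.28 log units; within the scatter)) and of the 4-hydroxy-3-methoxyphenyl group (a 1.1-fold lower number from compound 2 to compound 4 (0.03 log units; within the scatter)). Against the 3-hydroxyphenyl group the same position gives a second step beyond the scatter (a 2.3-fold lower number from compound 1 to compound 4 (0.37 log units; beyond the scatter)), so compound 1 now stands apart from both compound 2 and compound 4, while compound 3 remains within the scatter of all three others; the steps are modest, and the four aryl groups fill a narrow span. Compound 4 also shows that a six-membered aromatic ring with a hetero atom and no hydrogen-bond donor can sit level with compound 2, whose ring carries a hydroxy group, but nothing available here accounts for these numbers.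

From the compounds shown here alone, whether a plain phenyl, pyridin-3-yl or pyridin-2-yl group at this position would fall with compound 1 or with compound 4 stays open. So does the outcome of a dimethylamino group or a carboxylic acid on the ring, which would test whether the span stays this narrow.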